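Shortening the Acyl Chain: From Compound 2 to Compound 4

A few compounds are considered here, and "the series" means these few. Any claim that something is new, unique, unknown or untested is made for them only; others in the source may bear on it.

Measured so far in a functional assay on cells (Melanoma cell, Homo sapiens) for cytotoxicity, with a stated time of 72 h; a higher number here means that more compound is needed for the effect, a lower number that less compound is needed:
- Compound 1, `CCC(=O)C1=C(O)C(C)(C)C(O)=C(CC2=C(O)C(C)(C)C(O)=C(C(=O)CC)C2=O)C1=O`: compound 1 gives > 50 ug/mL, which is a limit of the assay and not a number.
- Compound 2, `CCC(=O)C1=C(O)C(C)(C)C(O)=C(Cc2c(O)c3c(c(C(=O)CC)c2O)OC(C)(C)C=C3)C1=O`: compound 2 gives 8 ug/mL.
- Compound 3, `CC(=O)C1=C(O)C(C)(CC=C(C)C)C(O)=C(Cc2c(O)c(CC=C(C)C)c(O)c(C(C)=O)c2O)C1=O`: compound 3 gives > 50 ug/mL, again only a limit.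

Within the data shown here, compound 2 therefore holds the only number in the set. Among the measured compounds shown here, the other two results sit at the limit of > 50 ug/mL in this assay, at which 2 of the 3 values shown sit, so no step between measured compounds can be sized, and no pattern across the three can be claimed; compound 1 and compound 3 simply show no effect up to that limit.

The next compound, compound 4, `CCC(=O)C1=C(O)C(C)(C)C(O)=C(Cc2c(O)c3c(c(C(C)=O)c2O)OC(C)(C)C=C3)C1=O`, differs from compound 2 in one place: hydrogen in place of methyl on a saturated chain carbon bound to a carbonyl carbon. For the measured compounds named here, no measured pair shows the effect of such a change on the shared core. The expected step is a 1.3-fold higher number from compound 2 to compound 4 (0.10 log units; within the scatter), which is no larger than the usual scatter of this assay. Compound 4 is estimated at 10 ug/mL, with a likely range from 4 ug/mL to 25 ug/mL.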

Compound 4, concentration for half-maximal effect: 5 ug/mL
For compound 4 the middle estimate is 2.0-fold (0.30 log units) above the measured one, and the stated range covers the measured number.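

In this assay, among these compounds, the first step that can be read is a 1.6-fold lower number from compound 2 to compound 4 (0.20 log units; within the scatter), for the change from ethyl to methyl, which also reads as propanoyl to acetyl. On a saturated chain carbon bound to a carbonyl carbon, hydrogen in place of methyl thus gives two values that cannot be told apart, so a measurable cytotoxic effect survives this shortening of the chain. Compound 1 and compound 3 remain at a limit of the assay and not at a number: the limit of > 50 ug/mL in this assay, at which 2 of the 4 values shown sit.

As far as these compounds go, what a longer chain such as butanoyl, or an amine, would give at this place remains open. Also open, from the compounds shown here alone, is whether the same shortening of the propanoyl group that compound 4 retains would give a step of similar size.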